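This account rests on a few compounds, and the source may have more. Where it says the series, first, only, none or still open, it means among the compounds named here.

Measured compounds:
- compound 1, `Nc1scc(CN2CCN(c3ccncc3)CC2)c1C(=O)c1ccc(Cl)cc1`, gives -4% in a functional assay on CHO cells with adenosine receptor A1 (Homo sapiens) as the target, read by cAMP accumulation and immunoassay, with a stated time of 6 min, tested at 0.01 uM; on this read-out lower numbers stand for a stronger effect and higher numbers for a weaker effect at the one concentration tested
- compound 2, `Nc1scc(CN2CCN(c3cccc(F)c3)CC2)c1C(=O)c1cccc(C(F)(F)F)c1`, gives -11%
- compound 3, `Nc1scc(CN2CCN(CCCc3ccc(Cl)cc3)CC2)c1C(=O)c1ccc(Cl)cc1`, gives 0%

The three measured compounds share one core and differ at the group on the amine nitrogen of the piperazine ring and at the aryl ketone. On this read-out all three numbers sit close together: the gap a number 4 percentage points higher from compound 1 to compound 3 (within the scatter) is within the scatter, and the gap between compound 1 and compound 2 is within the scatter too, so none of the three can be called more or less active than another.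

Compound 4, `Nc1scc(CN2CCN(c3cc(Cl)ccc3Cl)CC2)c1C(=O)c1ccc(Cl)cc1`, is not yet measured. It differs from compound 1 in one place: 2,5-dichlorophenyl in place of pyridin-4-yl on an amine nitrogen in a ring. Within the data shown here, the only measured step that bears on this position is a number 4 percentage points higher from compound 1 to compound 3 (within the scatter), where a much larger group replaced the same pyridin-4-yl without moving the number beyond the scatter. Compound 2, which carries a 3-fluorophenyl group on the same nitrogen, also gives a number within the scatter of compound 1. On this basis the change to compound 4 is expected to produce no step beyond the scatter, a number 1 percentage points higher from compound 1 to compound 4 (within the scatter). Compound 4 is therefore estimated at -3%, with a range from -15% to 10%.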

Compound 4, a percentage reported as activity, at one concentration (the size of the read-out at that concentration, not a potency): 13%
The estimate for compound 4 lay 16 percentage points below the measured number; the whole stated range lies below it.
By their numbers in this assay, from the lowest: compounds 2, 1 and 3 (each within the scatter of the next, the first and the last beyond it); then compound 4.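

In this assay the group on the amine nitrogen in a ring turns out to be able to move the number: 2,5-dichlorophenyl in place of pyridin-4-yl gives a number 17 percentage points higher from compound 1 to compound 4 (beyond the scatter), whereas the earlier change at this position stayed within the scatter. The same group in place of 3-(4-chlorophenyl)propyl gives a number 13 percentage points higher from compound 3 to compound 4 (beyond the scatter), so at the one concentration tested it reads as a weaker effect against both of the other groups at this position, though both steps are modest. Nothing at hand accounts for this shift.

The compounds shown leave open whether the step follows from the two chlorine atoms together, from one of them alone, or from the exchange of the pyridine ring for a ring of carbon only, a question that a plain phenyl or a 2-chlorophenyl group on the same nitrogen would help to separate. Also open, from the compounds shown here alone, is how a group such as 2-aminoethyl would read at this nitrogen, and whether these steps would hold at other concentrations.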